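Iodo analog of a vanilloid thiourea antagonist

The compounds below may be only part of what the source reports. "The series", "measured", "known", "first", "only" and "open" are said of these compounds alone.

Compound 1, `COc1cc(CNC(=S)NCC(COC(=O)C(C)(C)C)Cc2ccc(C)c(C)c2)ccc1O`, carries a 4-hydroxy-3-methoxybenzyl thiourea and a 3,4-dimethylphenyl arm; in a functional assay on CHO cells for antagonist activity at transient receptor potential cation channel subfamily V member 1 (Rattus norvegicus) (a lower number here means a stronger inhibitor, a higher number a weaker inhibitor), compound 1 is recorded as "not evaluated" (no result reported), so it stands on no number of its own. Among the measured compounds shown here, the only measured relative is compound 2, `COc1cc(CNC(=S)NCC(COC(=O)C(C)(C)C)Cc2ccc(C(C)(C)C)cc2)c(Br)cc1O`, which differs in several places at once; in this assay compound 2 gives 55 nM. Compound 3, `COc1cc(CNC(=S)NCC(COC(=O)C(C)(C)C)Cc2ccc(C)c(C)c2)cc(I)c1O`, is compound 1 with one change: iodo in place of hydrogen on an aromatic carbon. For the measured compounds named here, with no step between measured compounds to lean on, the expectation rests on the single value of compound 2, which bears a halogen in a comparable position. For compound 3 a modest gain in this assay over whatever compound 1 would show is expected, likely reaching beyond the usual scatter, though its size cannot be pinned down. Compound 3 is therefore estimated at 100 nM, within a range from 20 nM to 600 nM.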

Compound 3, inhibition constant: 121 nM
Compound 3: the middle estimate sits 1.2-fold (0.08 log units) below what was measured, and the stated range covers the measured number.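

Among the compounds shown here, compound 1 offers no single number in this assay and so no step to compound 3 at 121 nM can be read. As far as these compounds go, what the iodo group alone does to the core of compound 1 stays open. Nothing at hand explains the result.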